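From Compound 3 to Compound 4: A Hydroxyphenyl Exchange

A few compounds are considered here, and "the series" means these few. Any claim that something is new, unique, unknown or untested is made for them only; others in the source may bear on it.

In a functional assay on NCI-H460 cells (Homo sapiens) for inhibition, read by MTT assay, with a stated time of 72 h (on this read-out lower numbers stand for stronger inhibition and higher numbers for weaker inhibition), compound 1 `COc1cc(NC(C)CCCNC(=O)NNC(=O)Nc2ccc(Cl)cc2)c2ncccc2c1` gives 63000 nM, compound 2 `COc1cc(NC(C)CCCNC(=O)Nc2cccc(O)c2)c2ncccc2c1` gives 25000 nM and compound 3 `COc1cc(NC(C)CCCNC(=O)NNC(=O)Nc2cccc(F)c2)c2ncccc2c1` gives 50000 nM. Compound 3 therefore stands within the scatter of both other compounds. The data show a 1.3-fold lower number from compound 1 to compound 3 (0.10 log units; within the scatter), and also a 2.0-fold higher number from compound 2 to compound 3 (0.30 log units; within the scatter). Among the measured compounds shown here, only one measured step clears the scatter, namely a 2.5-fold lower number from compound 1 to compound 2 (0.40 log units; beyond the scatter).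

Compound 4 `COc1cc(NC(C)CCCNC(=O)Nc2ccc(O)cc2)c2ncccc2c1` is derived from compound 3 by placing 4-hydroxyphenyl in place of ((3-fluorophenyl)carbamoyl)amino on an amide-type nitrogen. For the measured compounds named here, no measured step makes exactly this exchange. Going by the values given here, the nearest precedent is compound 2, which carries 3-hydroxyphenyl on that nitrogen and gives 25000 nM. Among the compounds with values here, its two steps bear on the question, but they point only loosely: the exchange involving compound 1 lies beyond the scatter, while the one involving compound 3 does not. Within the data shown here, with only three compounds, and with no measured example of 4-hydroxyphenyl, a modest move to a lower number is expected, close to the limit of the scatter. The expected step is a 1.8-fold lower number from compound 3 to compound 4 (0.25 log units; within the scatter). The estimated value for compound 4 is 28000 nM, with an expected range from 12000 nM to 60000 nM.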

Compound 4, half-maximal inhibitory concentration: 34000 nM
Beside the measured number, compound 4's estimate is 1.2-fold (0.08 log units) below it; measured number inside the range.
By their numbers in this assay, from the lowest: compounds 2, 4, 3 and 1 (each within the scatter of the next, the first and the last beyond it).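

In this assay, among the compounds shown here, 4-hydroxyphenyl in place of 3-hydroxyphenyl on an amide-type nitrogen gives a 1.4-fold higher number from compound 2 to compound 4 (0.13 log units; within the scatter) and so the two hydroxyphenyl groups, the only such pair here, are not separated at this position. The exchange of the larger ((3-fluorophenyl)carbamoyl)amino for 4-hydroxyphenyl gives a 1.5-fold lower number from compound 3 to compound 4 (0.17 log units; within the scatter) and the exchange of ((4-chlorophenyl)carbamoyl)amino for the same group gives a 1.9-fold lower number from compound 1 to compound 4 (0.27 log units; within the scatter) and thus, unlike the 3-hydroxyphenyl exchange with a 2.5-fold lower number from compound 1 to compound 2 (0.40 log units; beyond the scatter) on the same nitrogen, neither clears the scatter, so the one separation beyond it stays with the 3-hydroxyphenyl group alone. Nothing available explains these numbers or the small differences among them.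

The four compounds leave open whether any group on this nitrogen can move the number well beyond the narrow span seen so far, since only hydroxyphenyl groups and two aryl carbamoylamino groups appear there. An aminophenyl or carboxyphenyl group on that nitrogen, 2-hydroxyphenyl, or a longer chain joining the shared core to the urea carbonyl would each test a part of the molecule that these compounds do not reach.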